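Aryloxypropyl piperazine amides: ethyl on the phenyl ring

The source may hold more compounds than are shown below. What is called first, only, known or untested is meant among the compounds shown, and "the series" means these compounds.

compound 1 `COc1ccccc1NC(=O)c1ccc(OCCCN2CCN(c3ccccc3OC)CC2)cc1`: 79.4 nM in an assay on Prostate gland (Oryctolagus cuniculus) for inhibition of Adrenergic receptor alpha-1 (Homo sapiens); on this read-out higher numbers stand for weaker binding and lower numbers for tighter binding
compound 2 `COc1ccccc1N1CCN(CCCCOc2ccc(C(=O)Nc3ccccc3OCCCC(=O)O)cc2)CC1`: 79.4 nM in this assay
compound 3 `COc1ccccc1N1CCN(CCC(Oc2ccc(NC(=O)c3ccccc3OCCCC(=O)O)cc2)c2ccccc2)CC1`: 79.4 nM in this assay

On the numbers at hand compound 3 stands level with compound 1 and compound 2; the three values lie within the scatter of one another, so no order among them can be read. Going by the values given here, no step between measured compounds differing in one place is available in this set.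

Compound 4 `CCc1ccc(C(CCN2CCN(c3ccccc3OC)CC2)Oc2ccc(NC(=O)c3ccccc3OCCCC(=O)O)cc2)cc1` differs from compound 3 by ethyl in place of hydrogen on an aromatic carbon, on an aromatic carbon of a six-membered aromatic ring of carbon only. Among the compounds with values here, with no comparable step measured, the expectation for this assay is a change no larger than the scatter, in either direction. The estimated step of a 1.1-fold lower number from compound 3 to compound 4 (0.05 log units; within the scatter) is therefore expected to stay within the scatter. Compound 4 is expected to give 70 nM, between 25 nM and 250 nM.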

Compound 4, dissociation constant: 200 nM
Beside the measured number, compound 4's estimate is 2.9-fold (0.46 log units) below it; the measured number falls inside the stated range.
By their numbers in this assay, from the lowest: compounds 1, 2 and 3 (each within the scatter of the next); then compound 4.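

Phenyl to 4-ethylphenyl, with the ethyl para to a large group, is the first single-place step in the series: a 2.5-fold higher number from compound 3 to compound 4 (0.40 log units; beyond the scatter) in this assay, towards weaker binding. The earlier compounds shown here sat level and gave no reading of any position, whereas this ring position now responds to substitution. Nothing at hand accounts for the shift.

Open, going by these compounds, is whether a shorter group such as methyl, or a single fluorine atom, at the same place would stay level with compound 3. Also open, on these data alone, is whether a longer chain such as propyl would move the number further.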